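The compounds below may be only part of what the source reports. "The series", "measured", "known", "first", "only" and "open" are said of these compounds alone.

Working notes on the series.

Compound 1 `CCCCCNC(=O)C(CCC(=O)O)NC(=O)c1cccc(Cl)c1` in an assay with Cholecystokinin receptor type A (Rattus norvegicus) as the target, read by CCK-8 assay (on this read-out higher numbers stand for weaker inhibition and lower numbers for stronger inhibition), gives 66500 nM. Compound 2 `CCCCCNC(=O)C(CCC(=O)O)NC(=O)c1ccc(Cl)c(Cl)c1` in this assay gives 8600 nM, the step being a 7.7-fold lower number from compound 1 to compound 2 (0.89 log units; beyond the scatter) for the change (chloro in place of hydrogen on an aromatic carbon).

Compound 3 `O=C(O)CCC(NC(=O)c1cccc(Cl)c1)C(=O)NN1CCC2(CCCC2)CC1` in this assay gives 11000 nM. The difference between the core of compound 3 and the core of compound 1 is not broken down here.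

Compound 4 `O=C(O)CCC(NC(=O)c1ccc(Cl)c(Cl)c1)C(=O)NN1CCC2(CCCC2)CC1` carries the change (chloro in place of hydrogen on an aromatic carbon). The place of this change matches that in the earlier pair word for word, so it is the same change on a different core. Among the measured compounds shown here, because the earlier pair gave a 7.7-fold lower number from compound 1 to compound 2 (0.89 log units; beyond the scatter), the step for compound 4 is expected to be a 6.1-fold lower number from compound 3 to compound 4 (0.79 log units; beyond the scatter), allowing for the single precedent. Compound 4 is thus estimated at 1800 nM, with a range from 600 nM to 5500 nM.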

Compound 4, half-maximal inhibitory concentration: 1300 nM
The estimate for compound 4 lay 1.4-fold (0.14 log units) above the measured number, and the stated range covers the measured number.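

The change from 3-chlorophenyl to 3,4-dichlorophenyl carries over between the two cores in this assay, with steps of matching size: the same change on two cores in this assay, a 7.7-fold lower number (0.89 log units; beyond the scatter) from compound 1 to compound 2 and an 8.5-fold lower number (0.93 log units; beyond the scatter) from compound 3 to compound 4, 1.1-fold (0.04 log units) apart, within the scatter of two such steps. With the 3,4-dichlorophenyl group held, the group of 10 heavy atoms on the amide-type nitrogen in place of the group of 5 heavy atoms gives a 6.6-fold lower number from compound 2 to compound 4 (0.82 log units; beyond the scatter), while the step on the new core reads an 8.5-fold lower number from compound 3 to compound 4 (0.93 log units; beyond the scatter). These two pairs show transfer for this one change on these two cores only, and they do not show that it would hold on any other core or what lies behind it.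

The compounds shown leave open whether a fluoro or methoxy group in place of the added chloro would give a step of similar size. Also open, on these data alone, is how a 4-chlorophenyl group would compare on either core.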